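Swapping the dihydroxyphenyl of compound 1 for bromophenyl

The compounds below may be only part of what the source reports. "The series", "measured", "known", "first", "only" and "open" are said of these compounds alone.

Compound 1, with structure `O=C(/C(=C\c1ccc(O)cc1O)Sc1ccc(Br)cc1)c1ccc(Cl)cc1`, was tested in a functional assay on DU-145 cells (Homo sapiens) for inhibition, read by trypan blue exclusion, with a stated time of 96 h (on this read-out lower numbers stand for stronger inhibition of growth and higher numbers for weaker inhibition of growth), where compound 1 gives 50000 nM. That is the highest of the two numbers measured. Among the compounds with values here, its only comparison, compound 2 with structure `Cc1ccc(C)c(/C=C(\C(=O)c2ccc(Br)cc2)S(=O)(=O)Cc2ccc(F)cc2)c1`, gives 1000 nM in this assay, a step beyond the scatter, but the two compounds differ in several places, so no single change can be read from them.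

Compound 3, with structure `O=C(/C(=C\c1ccc(Br)cc1)Sc1ccc(Br)cc1)c1ccc(Cl)cc1`, has not been measured. It differs from compound 1 in one place: 4-bromophenyl in place of 2,4-dihydroxyphenyl on a double-bonded chain carbon bound to a double-bonded chain carbon. Both hydrogen-bond donors of the dihydroxyphenyl are thus lost. Because compound 2 carries no hydrogen-bond donors on its aryl and gives 1000 nM, a lower number is expected for compound 3, with a step from compound 1 of a 5.0-fold lower number from compound 1 to compound 3 (0.70 log units; beyond the scatter) beyond the scatter. The estimate for compound 3 in this assay is 10000 nM, within a range from 2000 nM to 50000 nM.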

Compound 3, concentration for 50% growth inhibition: 1000 nM
Beside the measured number, compound 3's estimate is 10-fold (1.00 log units) above it; measured number below the stated range.
By their numbers in this assay, from the lowest: compounds 2 and 3 (each within the scatter of the next); then compound 1.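

In this assay, within the data shown here, the step of a 50-fold lower number from compound 1 to compound 3 (1.70 log units; beyond the scatter) gives the first reading of a single change, as the only earlier comparison involved compounds that differ in several places. It shows that the group on a double-bonded chain carbon bound to a double-bonded chain carbon matters greatly: with the rest of the molecule unchanged, 4-bromophenyl in place of 2,4-dihydroxyphenyl brings much stronger inhibition of growth. No measurement shown here explains this step.

As far as these compounds go, the change removes the hydroxyls and adds a bromine at once, so it remains open whether the loss of the former, the gain of the latter or both produce the step. A plain phenyl or a 4-methoxyphenyl in the same place would help to separate these possibilities.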